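A few compounds are considered here, and "the series" means these few. Any claim that something is new, unique, unknown or untested is made for them only; others in the source may bear on it.

Three compounds share one core and differ only in the group on a double-bonded ring carbon. Compound 1 `O=C1C(Nc2ccccc2)=CC(=O)c2c1nc1n2[C@H]2OC[C@@H](O)[C@H]2OC1` carries anilino, compound 2 `O=C1C(N2CCCC2)=CC(=O)c2c1nc1n2[C@H]2OC[C@@H](O)[C@H]2OC1` carries pyrrolidin-1-yl, and compound 3 `O=C1C(Nc2ccc(Br)cc2)=CC(=O)c2c1nc1n2[C@H]2OC[C@@H](O)[C@H]2OC1` carries (4-bromophenyl)amino. In a functional assay on HeLa cells (Homo sapiens) for inhibition, read by sulforhodamine B assay (a lower number here means a stronger inhibitor, a higher number a weaker inhibitor), compound 1 reaches only a limit, > 8000 nM. In this assay compound 2 also reaches only a limit, > 16000 nM. In this assay, among the measured compounds shown here, compound 3 gives 5220 nM, and this is the only outright number among the three. Compound 1 and compound 2 reach only limits, so compound 3 stands alone as the one measured point. Two steps can be read: an at least 1.5-fold lower number from compound 1 to compound 3 (0.18 log units; that floor lies within the scatter), and an at least 3.0-fold lower number from compound 2 to compound 3 (0.48 log units; beyond the scatter), while a step that the two limits leave unreadable from compound 1 to compound 2.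

Compound 4 `O=C1C(N2CCC2)=CC(=O)c2c1nc1n2[C@H]2OC[C@@H](O)[C@H]2OC1` is the next member: azetidin-1-yl in place of (4-bromophenyl)amino on a double-bonded ring carbon. The step that bears on it is the exchange between a small saturated nitrogen ring and the bromophenylamino group, seen as an at least 3.0-fold lower number from compound 2 to compound 3 (0.48 log units; beyond the scatter) in the reverse direction. Compound 4 carries azetidin-1-yl, a saturated nitrogen ring like the pyrrolidin-1-yl of compound 2. The step is therefore expected to run the other way, toward a higher number, as a 3.8-fold higher number from compound 3 to compound 4 (0.58 log units; beyond the scatter), most likely ending at a limit again. Compound 4 is estimated at 20000 nM in this assay, within a range from 8000 nM to 60000 nM.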

Compound 4, half-maximal inhibitory concentration: > 16000 nM
Compound 4: only a limit was reported; the forecaster's own chance of this, stated with the estimate: 80%; the middle value is on the limit's open side.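

Placing azetidin-1-yl on this double-bonded ring carbon in exchange for (4-bromophenyl)amino gives an at least 3.0-fold higher number from compound 3 to compound 4 (0.48 log units; beyond the scatter). Moving to this four-membered ring from the pyrrolidin-1-yl ring of compound 2 brings back no outright number, so neither saturated nitrogen ring has given a measured value here, and with limits at both ends the steps to compound 4 from compound 1 and from compound 2 cannot be read. Compound 3 therefore remains the only compound with an outright number, while the two saturated rings end at the same limit: the limit of > 16000 nM in this assay, at which 2 of the 4 values shown sit.

As far as these compounds go, it remains open how much of the gain in compound 3 belongs to the bromo group, as the anilino compound offers only a floor, an at least 1.5-fold lower number from compound 1 to compound 3 (0.18 log units; that floor lies within the scatter). A chloro or methoxy group in place of the bromo group, or an open-chain amine such as diethylamino on the same ring carbon, would show whether an outright number depends on the bromo group, the aromatic ring or the amino hydrogen.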